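Phenyl on the amide-type nitrogen of compound 2

The source may report more compounds than this note shows. Statements on the series, on what has been measured and on what is new or still open speak of the compounds shown alone.

Measured in a functional assay on ECa-109 cells (Homo sapiens) for antiproliferative activity, read by MTT assay, with a stated time of 48 h; a higher number here means a weaker inhibitor, a lower number a stronger inhibitor:
- compound 1 `Cn1cc(C2=C(c3nn(CCCn4cncn4)c4ncccc34)C(=O)N(c3ccccc3)C2=O)c2ccccc21`: > 100000 nM
- compound 2 `Cn1cc(C2=C(c3nn(CCCCn4ccnc4)c4ncccc34)C(=O)NC2=O)c2ccccc21`: 23500 nM

In this assay, for the measured compounds named here, compound 2 gives 23500 nM, the only actual number so far in this small set. Compound 1 reads > 100000 nM, which is a limit and not a number. That leaves compound 2 as the sole quantified reference point for the series.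

The next entry is compound 3 `Cn1cc(C2=C(c3nn(CCCCn4ccnc4)c4ncccc34)C(=O)N(c3ccccc3)C2=O)c2ccccc21`, which is derived from compound 2 by one change: phenyl in place of hydrogen on an amide-type nitrogen in a ring. This places phenyl in place of hydrogen on an amide-type nitrogen in a ring.

Going by the values given here, no measured pair isolates this change, so any expected step rests on thin evidence. Compound 1 also carries phenyl on that nitrogen, although it is not a direct match for compound 3 elsewhere in the structure. On that single indication, a moderate weakening beyond the usual scatter is expected, and a result reported only as a limit would not be surprising.

For compound 3 the estimated value is 50000 nM, with an expected range of 15000 nM to 150000 nM. The expected change is a 2.1-fold higher number from compound 2 to compound 3 (0.33 log units; beyond the scatter).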

Compound 3, half-maximal inhibitory concentration: 7540 nM
For compound 3 the middle estimate is 6.6-fold (0.82 log units) above the measured one, and the stated range ends above it.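

In this assay, the amide hydrogen is not required for activity in this pair: phenyl in place of hydrogen on the amide-type nitrogen in a ring gives a 3.1-fold lower number from compound 2 to compound 3 (0.49 log units; beyond the scatter). With phenyl held on that nitrogen, (1H-imidazol-1-yl)methyl in place of 1H-1,2,4-triazol-1-yl on a saturated chain carbon gives an at least 13-fold lower number from compound 1 to compound 3 (1.12 log units; beyond the scatter), so the phenyl alone does not account for the weak reading of compound 1. The reading for compound 1 is a limit and not a number, so this second step has no fixed size: the limit of > 100000 nM in this assay, at which 1 of the 3 values shown sits.

Going by these compounds, the gain from phenyl rests on a single pair, and it remains open whether methyl, benzyl or 4-methoxyphenyl on the same nitrogen would give a similar step, or whether a substituted phenyl could give a much lower number than compound 3, which gives 7540 nM. On these data alone, it also remains open how the chain and the terminal ring contribute separately, which a 1H-1,2,4-triazol-1-yl group on the longer chain of compound 3 would help to resolve.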